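The compounds below may be only part of what the source reports. "The series", "measured", "known", "first", "only" and "open" are said of these compounds alone.

Compound 1 `CNc1nc(N)nc2c1ncn2/C=C1/CC1(CO)CO`: 67000 nM
Compound 2 `CCCNc1nc(N)nc2c1ncn2/C=C1/CC1(CO)CO`: > 20000 nM

Of the compounds shown here, two have so far been measured in an ADME assay on BCBL1 cells (Homo sapiens) for cytotoxicity, with a stated time of 7 days; on this read-out higher numbers stand for lower toxicity in this test and lower numbers for higher toxicity in this test. Compound 1 (`CNc1nc(N)nc2c1ncn2/C=C1/CC1(CO)CO`) gives 67000 nM in this assay. For compound 2 (`CCCNc1nc(N)nc2c1ncn2/C=C1/CC1(CO)CO`) this assay reports only a limit, > 20000 nM. The step between them, ethyl in place of hydrogen on a saturated chain carbon bound to a nitrogen on an aromatic ring, is a step that the limit leaves unreadable from compound 1 to compound 2; its size cannot be read because the limit of > 20000 nM in this assay, at which 1 of the 2 values shown sits, hides one end of it. Compound 2 therefore stands on the numbers shown only as a limit.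

Compound 3 (`CCCCOc1nc(N)nc2c1ncn2/C=C1/CC1(CO)CO`) has not yet been measured. Against compound 2 its change is butoxy in place of propylamino on an aromatic carbon. Among the measured compounds shown here, the single measured step concerns a different place on the shared core and is itself unreadable, so no measured step bears directly on this change. Lacking a readable step, the expectation for compound 3 in this assay is a step of no size beyond the scatter, a step that the limit leaves unreadable from compound 2 to compound 3. Compound 3 is accordingly estimated at 50000 nM, expected to lie between 15000 nM and 200000 nM.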

Compound 3, half-maximal cytotoxic concentration: > 20000 nM
Compound 3 was reported as a limit; the forecaster's own chance of this, stated with the estimate: 60%; the middle value does not contradict the limit.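

In this assay compound 3 gives > 20000 nM as a limit and not a number. Among the compounds shown here, no new step between compound 3 and compound 1 or compound 2 can be read, because the comparison rests on this: the limit of > 20000 nM in this assay, at which 2 of the 3 values shown sit. The compounds shown leave open how butoxy compares with propylamino or methylamino on that aromatic carbon in this assay.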